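Swapping hydroxyphenyl groups on a cytotoxic pyridine scaffold

This account rests on a few compounds, and the source may have more. Where it says the series, first, only, none or still open, it means among the compounds named here.

Measured so far:
- compound 1 `Oc1ccc(-c2cc(-c3ccccc3O)cc(-c3ccccc3O)n2)cc1`: 8240 nM
- compound 2 `Oc1ccc(-c2cc(-c3ccccc3O)cc(-c3ccc(O)cc3)n2)cc1`: 1920 nM

In a functional assay on HCT-15 cells (Homo sapiens) for cytotoxicity, read by CCK-8 assay, with a stated time of 4 days (on this read-out higher numbers stand for weaker inhibition and lower numbers for stronger inhibition), compound 1 gives 8240 nM, the highest of the two numbers, while compound 2 gives 1920 nM. Going by the values given here, the only measured step is a 4.3-fold lower number from compound 1 to compound 2 (0.63 log units; beyond the scatter). Compound 3 `Oc1ccccc1-c1cc(-c2ccccc2O)nc(-c2ccccc2O)c1` moves the other way: 2-hydroxyphenyl in place of 4-hydroxyphenyl on an aromatic carbon. Since placing a 4-hydroxyphenyl group lowered the number, the reverse exchange is expected to raise it, and a rise is estimated as a 3.0-fold higher number from compound 1 to compound 3 (0.48 log units; beyond the scatter). Compound 3 is therefore expected to give about 25000 nM, within a range of 10000 nM to 60000 nM.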

Compound 3, half-maximal inhibitory concentration: 2180 nM
Beside the measured number, compound 3's estimate is 11-fold (1.06 log units) above it; measured number outside the range, below it.
By their numbers in this assay, from the lowest: compounds 2 and 3 (each within the scatter of the next); then compound 1.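

Exchanging the 4-hydroxyphenyl next to the ring nitrogen for 2-hydroxyphenyl also lowers the number in this assay, giving a 3.8-fold lower number from compound 1 to compound 3 (0.58 log units; beyond the scatter). The exchange therefore does not act as a simple reverse of the earlier step: both changes made from compound 1 lower the number, and each leaves the two groups next to the ring nitrogen alike. No evidence is available to explain this result.
Still open, as far as these compounds go, is how the number would respond if an amine or a methoxy group replaced a hydroxyl on these rings.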